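Two Aryl Groups Traded on the Same Aromatic Nitrogen

A few compounds are considered here, and "the series" means these few. Any claim that something is new, unique, unknown or untested is made for them only; others in the source may bear on it.

Measured so far:
compound 1 `N#CC1=C(N)Oc2c(c3nc4ccccc4nc3c3ccccc23)C12C(=O)N(Cc1cnnn1-c1ccccc1Cl)c1ccccc12` — > 50000 nM
compound 2 `N#CC1=C(N)Oc2c(c3nc4ccccc4nc3c3ccccc23)C12C(=O)N(Cc1cnnn1-c1cccc(S(N)(=O)=O)c1)c1ccccc12` — 42500 nM

Both compounds share one core and differ only in the aryl group carried on an aromatic nitrogen. In a functional assay on MCF7 cells (Homo sapiens) for antiproliferative activity, read by MTT assay, with a stated time of 48 h (on this read-out lower numbers stand for stronger inhibition and higher numbers for weaker inhibition), compound 1 reaches only a limit of the assay, > 50000 nM, and not a number (the limit of > 50000 nM in this assay, at which 1 of the 2 values shown sits). Compound 2 gives the only number shown, 42500 nM, so it is the sole fixed point among the values. Among the compounds with values here, the one measured step is an at least 1.1-fold lower number from compound 1 to compound 2 (0.07 log units; that floor lies within the scatter), and it sits at a floor that lies within the scatter, so it shows no clear change.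

Compound 3 `N#CC1=C(N)Oc2c(c3nc4ccccc4nc3c3ccccc23)C12C(=O)N(Cc1cnnn1-c1cc(Cl)ccc1Cl)c1ccccc12` is the next member. The change from compound 2 is 2,5-dichlorophenyl in place of 3-sulfamoylphenyl on an aromatic nitrogen. Within the data shown here, the only step that bears on it is the aryl swap at the same position, which gave no movement beyond the scatter. A step of about the same small size, or none beyond the scatter, is therefore expected in this assay, so compound 3 is estimated at 50000 nM, ranging from 20000 nM to 150000 nM, which would mean a step of a 1.2-fold higher number from compound 2 to compound 3 (0.07 log units; within the scatter).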

Compound 3, half-maximal inhibitory concentration: > 50000 nM
Compound 3: no number, only a limit; the forecaster's own chance of this, stated with the estimate: 55%; the middle value lies on the limit itself.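

Setting 2,5-dichlorophenyl in place of 3-sulfamoylphenyl on this aromatic nitrogen gives an at least 1.1-fold higher number from compound 2 to compound 3 (0.07 log units; that floor lies within the scatter), so a group with 0 hydrogen-bond donors and 0 hydrogen-bond acceptors has now been seen at this position, and the readable step still shows no change beyond the scatter. The step between compound 1 and compound 3 joins two limits of the assay, not two numbers, and cannot be read. With two chlorophenyl groups at this position in this assay, limits now make up most of the values, which leaves compound 2 as the only fixed number in the series: the limit of > 50000 nM in this assay, at which 2 of the 3 values shown sit.

As far as these compounds go, all three groups on this nitrogen are substituted phenyl rings, and none of them gives a value clearly separated from the others, so it remains open whether any change at this position can move the value beyond the scatter. A phenyl ring carrying an amine or a carboxylic acid, or a longer chain in place of the ring, would extend the comparison to kinds of group not covered by the compounds shown.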